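This account rests on a few compounds, and the source may have more. Where it says the series, first, only, none or still open, it means among the compounds named here.

Measured in an ADME assay on Vero cells (Chlorocebus sabaeus) for cytotoxicity, read by CellTiter-Glo, with a stated time of 72 h; on this read-out higher numbers stand for lower toxicity in this test and lower numbers for higher toxicity in this test:
compound 1 `[O-][n+]1nc(NC2CC2)[n+]([O-])c2ccc(F)cc21`, 1.3 ug/mL
compound 2 `[O-][n+]1nc(NC2CCC2)[n+]([O-])c2ccc(F)cc21`, 1.6 ug/mL
compound 3 `[O-][n+]1nc(NC2CC2)[n+]([O-])c2ccc(Cl)cc21`, 1.3 ug/mL

Compound 2 differs from compound 1 by cyclobutyl in place of cyclopropyl on a nitrogen on an aromatic ring, and that change gave a step of a 1.2-fold higher number from compound 1 to compound 2 (0.09 log units; within the scatter). Compound 3 differs from compound 1 by chloro in place of fluoro on an aromatic carbon, with a step of no change at the digits printed from compound 1 to compound 3 (within the scatter). Compound 4 `[O-][n+]1nc(NC2CCC2)[n+]([O-])c2ccc(Cl)cc21` is not yet measured in this assay. Going by the values given here, it differs from compound 3 by cyclobutyl in place of cyclopropyl on a nitrogen on an aromatic ring, the same change as the one from compound 1 to compound 2, here made on the core that carries chloro rather than fluoro. Because the earlier step of a 1.2-fold higher number from compound 1 to compound 2 (0.09 log units; within the scatter) lies within the scatter, and because compound 3 gives 1.3 ug/mL, little movement is expected. Compound 4 is therefore expected to show a step of a 1.2-fold higher number from compound 3 to compound 4 (0.06 log units; within the scatter). This rests on one earlier pair only. Compound 4 is estimated at 1.5 ug/mL, from 0.9 ug/mL to 2.6 ug/mL.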

Compound 4, half-maximal cytotoxic concentration: 1.6 ug/mL
Compound 4: the middle estimate sits 1.1-fold (0.03 log units) below what was measured, and the stated range covers the measured number.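

In this assay, cyclobutyl in place of cyclopropyl gives a 1.2-fold higher number from compound 3 to compound 4 (0.09 log units; within the scatter), matching what the same swap did on the fluoro core: the same change on two cores in this assay, a 1.2-fold higher number (0.09 log units; within the scatter) from compound 1 to compound 2 and a 1.2-fold higher number (0.09 log units; within the scatter) from compound 3 to compound 4, 1.0-fold (0.00 log units) apart, within the scatter of two such steps

Chloro in place of fluoro gives no change at the digits printed from compound 2 to compound 4 (within the scatter), and this too matches the earlier pair: the same change on two cores in this assay, no change at the digits printed (within the scatter) from compound 1 to compound 3 and no change at the digits printed (within the scatter) from compound 2 to compound 4, 1.0-fold (0.00 log units) apart, within the scatter of two such steps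

Going by these compounds alone, all of these steps lie within the scatter, so the agreement shows only that neither change visibly moves this number on these cores, not that a change with a real effect would carry over from one core to another in the same way.

The compounds shown leave open whether a cyclohexyl group or an open chain such as ethyl on the nitrogen would shift the number beyond the scatter. The same question stands for a methoxy group or a nitrile in place of the halogen.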